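Selenium in Place of Sulfur on the Cyano-Bearing Chain

The source may report more compounds than this note shows. Statements on the series, on what has been measured and on what is new or still open speak of the compounds shown alone.

Measured so far in a functional assay on MCF7 cells (Homo sapiens) for cytotoxicity, read by MTT assay, with a stated time of 72 h; on this read-out lower numbers stand for stronger inhibition of growth and higher numbers for weaker inhibition of growth:
compound 1 `O=C1c2ccccc2C(=O)N1C[SeH]`: 6000 nM
compound 2 `N#CSCN1C(=O)c2ccccc2C1=O`: 48100 nM

Compound 2 gives the highest of the two numbers; compound 1 sits at the lower one. Compound 3 `N#C[Se]CN1C(=O)c2ccccc2C1=O` differs from compound 2 by a group of 3 heavy atoms (1 carbon, 1 nitrogen, 1 selenium; no ring) in place of a group of 3 heavy atoms (1 carbon, 1 nitrogen, 1 sulfur; no ring), on a saturated chain carbon bound to an amide-type nitrogen in a ring. Among the compounds with values here, the one measured step that bears on this is an 8.0-fold higher number from compound 1 to compound 2 (0.90 log units; beyond the scatter), where a selenium atom gave way to a sulfur-containing group. Putting selenium back, now as part of the cyano-bearing group, is expected to move the number down, though more modestly. Compound 3 is therefore estimated at 12000 nM, with a range from 4000 nM to 40000 nM, an expected step of a 4.0-fold lower number from compound 2 to compound 3 (0.60 log units; beyond the scatter).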

Compound 3, concentration for 50% growth inhibition: 15400 nM
Compound 3: middle estimate off by 1.3-fold (0.11 log units), on the low side; measured number inside the range.
By their numbers in this assay, from the lowest: compound 1; then compound 3; then compound 2.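

In this assay, exchanging only sulfur for selenium within the cyano-bearing group gives a 3.1-fold lower number from compound 2 to compound 3 (0.49 log units; beyond the scatter), so the identity of this atom matters even with the nitrile kept. Cyano in place of hydrogen on a selenium gives a 2.6-fold higher number from compound 1 to compound 3 (0.41 log units; beyond the scatter), so the earlier gap resolves into two separate steps, each beyond the scatter. No measurement at hand explains either step.

The compounds shown leave open how a thiol, the sulfur counterpart of compound 1, would compare at this place. They also leave open how a methyl group or a longer chain on the selenium would read.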